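A few compounds are considered here, and "the series" means these few. Any claim that something is new, unique, unknown or untested is made for them only; others in the source may bear on it.

Working notes on the series in an ADME assay on HepG2 cells (Homo sapiens) for cytotoxicity; a higher number here means that more compound is needed for the effect, a lower number that less compound is needed. Compound 1 (`Cc1ccc(S(=O)(=O)N[C@@H](CC(=O)NC(C)(C)C)C(=O)NCCNC(=O)c2ccc(Cl)cc2)cc1`) gives > 11000 nM as a limit of the assay, not a number. Compound 2 (`Cc1ccc(S(=O)(=O)N[C@@H](CC(=O)NC(C)(C)C)C(=O)NCCNC(=O)c2cc(C)ccc2F)cc1`) gives > 11000 nM as a limit too, so its position is known only as a limit and not as a measured value.

The next compound, compound 3 (`Cc1ccc(S(=O)(=O)N[C@@H](CC(=O)NC(C)(C)C)C(=O)NCCNC(=O)c2cc(C)ccn2)cc1`), carries 4-methylpyridin-2-yl in place of 2-fluoro-5-methylphenyl on a carbonyl carbon, with the rest of the structure unchanged.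

Among the compounds with values here, only one measured step bears on this change, since it falls at the same carbonyl carbon: a step that the two limits leave unreadable from compound 1 to compound 2 gives no usable size. Within the data shown here, what remains is the limit of > 11000 nM in this assay, at which 2 of the 2 values shown sit, as the sole guide. No step beyond the scatter is therefore expected in this assay, and no direction can be argued. The expected step is a step that the limit leaves unreadable from compound 2 to compound 3 and should most likely be unreadable if another limit is reported. Compound 3 is estimated at 15000 nM with an expected range from 8000 nM to 30000 nM as the likely span.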

Compound 3, half-maximal effective concentration: > 11000 nM
Compound 3 was reported as a limit; the forecaster's own chance of this, stated with the estimate: 85%; the middle value lies beyond the limit too.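

In this assay compound 3 gives > 11000 nM, a limit of the assay and not a number. The steps among compound 1, compound 2 and compound 3 therefore cannot be read, and the values offer only this: the limit of > 11000 nM in this assay, at which 3 of the 3 values shown sit.

The compounds shown leave open whether any group on this carbonyl carbon would give a readable value in this assay.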